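The source may hold more compounds than are shown below. What is called first, only, known or untested is meant among the compounds shown, and "the series" means these compounds.

Measured so far in an assay on cells for activation of probable G-protein coupled receptor 34 (Mus musculus), with a stated time of 1 h; on this read-out lower numbers stand for smaller maximal responses and higher numbers for larger maximal responses:
- compound 1 `N[C@@H](COP(=O)(O)OCCCOC(=O)CCc1ccccc1OCc1cccc(Oc2ccccc2Cl)c1)C(=O)O`: 0.069
- compound 2 `N[C@@H](COP(=O)(O)OCCCOC(=O)CCc1ccccc1OCc1cccc(Oc2ccc(Cl)cc2)c1)C(=O)O`: 0.76
- compound 3 `N[C@@H](COP(=O)(O)OCCCOC(=O)CCc1ccccc1OCc1cccc(Oc2ccc(F)cc2)c1)C(=O)O`: 0.66

Compound 3 holds the second highest of the three numbers in this assay. Its nearest neighbour is compound 2: the step a number 0.10 lower from compound 2 to compound 3 (within the scatter) lies within the scatter, so the two read as equal. Its furthest neighbour is compound 1: the step a number 0.59 higher from compound 1 to compound 3 (beyond the scatter) is large and beyond the scatter, as is a number 0.69 higher from compound 1 to compound 2 (beyond the scatter). Among the compounds with values here, of the three, only compound 1 is clearly set apart, so moving the halogen from the 2-position of the phenoxy ring to the 4-position is the one change seen so far that matters, while swapping chloro for fluoro at the 4-position does not.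

Compound 4 `CCc1ccc(Oc2cccc(COc3ccccc3CCC(=O)OCCCOP(=O)(O)OC[C@H](N)C(=O)O)c2)cc1` keeps the 4-substituted phenoxy arrangement of compounds 2 and 3 and differs from compound 3 by ethyl in place of fluoro on an aromatic carbon. Within the data shown here, the only measured step at that same place, a number 0.10 lower from compound 2 to compound 3 (within the scatter), was within the scatter, which suggests the 4-substituent is tolerated, but no measured step covers ethyl in place of a halogen, so the estimate carries wide uncertainty. The expectation for this assay is therefore a step a number 0.040 lower from compound 3 to compound 4 (within the scatter) of no clear direction, and compound 4 is estimated at 0.62 with a range of 0.35 to 0.85.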

Compound 4, intrinsic activity: the largest response reached, as a fraction of the reference agonist's: 0.42
For compound 4 the middle estimate is 0.20 above the measured one; the measured number falls inside the stated range.
By their numbers in this assay, from the lowest: compound 1; then compound 4; then compounds 3 and 2 (each within the scatter of the next).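

In this assay, the group on this aromatic carbon, para to a large group, is less freely exchangeable than the halogen pair suggested: ethyl in place of fluoro gives a number 0.24 lower from compound 3 to compound 4 (beyond the scatter), and ethyl in place of chloro gives a number 0.34 lower from compound 2 to compound 4 (beyond the scatter), so this place separates ethyl from both halogens even though compound 2 and compound 3 read as equal. The change does not cancel the gain seen with the 4-substituted rings, since 4-ethylphenyl in place of 2-chlorophenyl still gives a number 0.35 higher from compound 1 to compound 4 (beyond the scatter), leaving compound 4 at an intermediate level between compound 1 and the two halogen compounds. Nothing available accounts for the loss of maximal response with ethyl.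

From the compounds shown here alone, it remains open whether the response changes stepwise through methyl, ethyl and a longer chain such as propyl at this place, or whether an amine or a carboxylic acid there could restore the level of compound 2 and compound 3. Also open, going by these compounds, is whether a 2-ethylphenyl group would fall as low as the 2-chlorophenyl group of compound 1, at 0.069.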